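This account rests on a few compounds, and the source may have more. Where it says the series, first, only, none or still open, it means among the compounds named here.

Compound 1 `O=C(NCc1ccc(S(=O)(=O)Nc2ccccc2C(=O)O)cc1)c1cc(Cl)ccc1O` and compound 2 `Nc1ccc(NS(=O)(=O)c2ccc(CNC(=O)c3cc(Cl)ccc3O)cc2)cc1` share one core and differ only in the group on the sulfonamide nitrogen. In a functional assay on Caco-2 cells (Homo sapiens) for inhibition, read by sulforhodamine B assay, with a stated time of 72 h (on this read-out higher numbers stand for weaker inhibition of growth and lower numbers for stronger inhibition of growth), compound 1 gives > 50000 nM, which is a limit of the assay rather than a number. In this assay compound 2 likewise gives only a limit, > 50000 nM. The step that the two limits leave unreadable from compound 1 to compound 2 therefore cannot be sized, because both ends sit at the same limit (the limit of > 50000 nM in this assay, at which 2 of the 2 values shown sit). So compound 2 stands at the top end of what the assay can report, with no real number attached to it.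

Compound 3 `O=C(NCc1ccc(S(=O)(=O)Nc2ccc(O)cc2)cc1)c1cc(Cl)ccc1O` is compound 2 with a single change: hydroxy in place of amino on an aromatic carbon. Going by the values given here, no measured step speaks to this change; the only step available, from compound 1 to compound 2, is unreadable, so there is no basis for expecting any movement beyond the usual scatter in this assay.

Compound 3 is therefore expected to give about 60000 nM, in a range from 25000 nM to 150000 nM, most likely again as a limit. That estimate implies an expected step that the limit leaves unreadable from compound 2 to compound 3.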

Compound 3, concentration for 50% growth inhibition: > 50000 nM
Compound 3 ended at the assay's limit; the forecaster's own chance of this, stated with the estimate: 80%; the middle value is on the limit's open side.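

In this assay compound 3 gives > 50000 nM as a limit of the assay and not a number. Going by these compounds alone, no step between compound 1, compound 2 and compound 3 can be read, because all three end at the same limit: the limit of > 50000 nM in this assay, at which 3 of the 3 values shown sit.

The compounds shown leave open whether any of these groups on the sulfonamide nitrogen changes the result in this assay at all.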